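Trimming a Methoxy Group on a Shared Core

This account rests on a few compounds, and the source may have more. Where it says the series, first, only, none or still open, it means among the compounds named here.

Measured so far in a functional assay on FM3A cells (Mus musculus) for inhibition, read by cell counting, with a stated time of 2 days; on this read-out lower numbers stand for stronger inhibition and higher numbers for weaker inhibition:

- compound 1, `Nc1cccc(-c2cn3nc(Cc4ccccc4)sc3n2)c1`, gives 4700 nM
- compound 2, `COc1ccc(-c2nn3cc(-c4cccc(N)c4)nc3s2)cc1OC`, gives 13000 nM
- compound 3, `COc1ccc(Cc2nn3cc(-c4cccc(N)c4)nc3s2)cc1`, gives 100000 nM

Compound 4, `COc1ccc(-c2nn3cc(-c4cccc(N)c4)nc3s2)cc1`, has not yet been measured in this assay. It arises from compound 2 by a single change, (hydrogen in place of methoxy on an aromatic carbon). The same change has already been made once among the measured compounds, from compound 3 to compound 1, (hydrogen in place of methoxy on an aromatic carbon), where it produced a 21-fold lower number from compound 3 to compound 1 (1.33 log units; beyond the scatter) in this assay. The two cases are the same kind of change rather than the same change: in compound 3 the leaving methoxy sits para to a large group, whereas in compound 2 it sits ortho to a methoxy group and meta to a large group. How the cores of compound 2 and compound 3 differ is not broken down here; their values in this assay simply show compound 2 with the lower number of the two.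

Because the earlier step of a 21-fold lower number from compound 3 to compound 1 (1.33 log units; beyond the scatter) was large, a move in the same direction is expected for compound 4, yet the different surroundings of the methoxy make a smaller step the more cautious expectation, a 2.2-fold lower number from compound 2 to compound 4 (0.34 log units; beyond the scatter). Compound 4 is therefore estimated at 6000 nM in this assay, expected to lie between 2000 nM and 20000 nM.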

Compound 4, half-maximal inhibitory concentration: 74000 nM
Beside the measured number, compound 4's estimate is 12-fold (1.09 log units) below it; the whole stated range lies below it.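

In this assay, putting hydrogen in place of the methoxy group on compound 2 gives a 5.7-fold higher number from compound 2 to compound 4 (0.76 log units; beyond the scatter), so this time the loss of a methoxy group goes with weaker inhibition, not stronger. The same swap therefore cannot be assumed to carry from one core to another in this series, even in its direction: the same change on two cores in this assay, a 21-fold lower number (1.33 log units; beyond the scatter) from compound 3 to compound 1 and a 5.7-fold higher number (0.76 log units; beyond the scatter) from compound 2 to compound 4, 120-fold (2.08 log units) apart, beyond the scatter of two such steps. For the compounds shown here, this does not show why the two cases part ways, since they are only two pairs that differ both in their cores and in what surrounds the methoxy group that leaves, and the numbers cannot separate these two differences or say that either one is responsible.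

From the compounds shown here alone, what stays open is whether another group at the same place on the ring, ortho to a methoxy group, such as a hydroxyl group, a fluorine atom or a longer ethoxy chain, would stay close to the number of compound 2 or move towards that of compound 4. Also open, going by these compounds, is whether replacing the remaining methoxy group of compound 4 with hydrogen would weaken inhibition further or restore some of it.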